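Working notes: compound 2 to compound 3

A few compounds are considered here, and "the series" means these few. Any claim that something is new, unique, unknown or untested is made for them only; others in the source may bear on it.

In a functional assay on MCF7 cells (Homo sapiens) for cytotoxicity, read by neutral red uptake, with a stated time of 3 days (on this read-out higher numbers stand for weaker inhibition and lower numbers for stronger inhibition), compound 1 (`Cc1c(F)c(N)c2c(=O)cc(-c3ccc(N)c(F)c3)oc2c1F`) gives 13 nM. Compound 2 (`CCCCCCc1c(F)c(N)c2c(=O)cc(-c3ccc(N)c(F)c3)oc2c1F`) gives > 10000 nM, a limit of the assay and not a number. Compound 3 (`C[S+]([O-])c1c(F)c(N)c2c(=O)cc(-c3ccc(N)c(F)c3)oc2c1F`) follows from compound 2 by a group of 3 heavy atoms (1 carbon, 1 oxygen, 1 sulfur; no ring) in place of a group of 6 heavy atoms (6 carbon; no ring), on an aromatic carbon. The site is ortho to two fluoro groups and meta to an amino group. For the measured compounds named here, one measured step bears on this site: an at least 760-fold higher number from compound 1 to compound 2 (2.88 log units; beyond the scatter), large and beyond the scatter. Compound 3 loses the hexyl chain, but its entering group is the same as that of neither measured compound, so a full return to the value of compound 1 is not assumed. A large step toward lower numbers is therefore expected in this assay, and the expected size is an at least 33-fold lower number from compound 2 to compound 3 (1.52 log units; beyond the scatter). For compound 3 the estimated value is 300 nM, with an expected range of 40 nM to 3000 nM.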

Compound 3, half-maximal inhibitory concentration: 2500 nM
The estimate for compound 3 lay 8.3-fold (0.92 log units) below the measured number; the range from low to high includes it.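

In this assay, the group of 3 heavy atoms on this aromatic carbon, ortho to two fluoro groups, gives an at least 4.0-fold lower number from compound 2 to compound 3 (0.60 log units; beyond the scatter), so losing hexyl recovers some inhibition. The recovery is partial, with the methyl group and the new group separated by a 190-fold higher number from compound 1 to compound 3 (2.28 log units; beyond the scatter), which shows that removing the long chain is not enough to restore the low number and that this position also distinguishes between small groups. Compound 2 stands at a limit of the assay and not at a number, so the first of these steps is only a bound: the limit of > 10000 nM in this assay, at which 1 of the 3 values shown sits.

Going by these compounds, whether an amine or a carboxylic acid at this carbon would come closer to compound 1 remains open. On these data alone, how the number changes with chain length between methyl and hexyl, for example with an ethyl or propyl chain, also remains open.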